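This account rests on a few compounds, and the source may have more. Where it says the series, first, only, none or still open, it means among the compounds named here.

The study examines thioacrylic acids as inhibitors in an assay on isolated protein for inhibition of Calpain-1 catalytic subunit (Sus scrofa); on this read-out lower numbers stand for stronger inhibition and higher numbers for weaker inhibition. Compound 1 `O=C(O)/C(S)=C/c1ccc(Br)cc1` gives 1500 nM in this assay, and compound 3 `O=C(O)/C(S)=C/c1ccc(Cl)cc1` gives 15000 nM. Going by the values given here, the two differ by one change, (chloro in place of bromo on an aromatic carbon), and the step of a 10-fold higher number from compound 1 to compound 3 (1.00 log units; beyond the scatter) is the only measured example of this change. Compound 2 `O=C(O)/C(S)=C/c1c[nH]c2c(Br)cccc12` gives 70 nM, the lowest number among the three measured compounds; the difference between the cores of compound 1 and compound 2 is not broken down here.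

Compound 4 `O=C(O)/C(S)=C/c1c[nH]c2c(Cl)cccc12` has not yet been measured in this assay. Relative to compound 2 it carries the change (chloro in place of bromo on an aromatic carbon). This is the same kind of change as in the pair of compound 1 and compound 3, but the place differs: in compound 3 the chloro sits para to a group of 6 heavy atoms, whereas in compound 4 it sits on a ring that is part of a fused system of two rings, ortho to a fused ring and meta to a fused ring. Resting only on the step of a 10-fold higher number from compound 1 to compound 3 (1.00 log units; beyond the scatter) from compound 1 to compound 3, a weaker inhibition is expected for compound 4, with an estimated step of a 7.1-fold higher number from compound 2 to compound 4 (0.85 log units; beyond the scatter). Compound 4 is therefore estimated at 500 nM, within a range from 150 nM to 2000 nM.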

Compound 4, half-maximal inhibitory concentration: 90 nM
Compound 4: middle estimate off by 5.6-fold (0.74 log units), on the high side; the measured number lies below the stated range.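

On the core of compound 2, chloro in place of bromo gives a 1.3-fold higher number from compound 2 to compound 4 (0.11 log units; within the scatter) in this assay, so on this core the two halogens cannot be told apart. These two pairs cannot show which feature of the cores sets the size of the step, or how large the step would be on a third core. They do show that the size of this change, read on one core, did not carry over to the other: the same change on two cores in this assay, a 10-fold higher number (1.00 log units; beyond the scatter) from compound 1 to compound 3 and a 1.3-fold higher number (0.11 log units; within the scatter) from compound 2 to compound 4, 7.8-fold (0.89 log units) apart, beyond the scatter of two such steps

The compounds shown leave open how the core of compound 2 responds to other groups on that aromatic carbon, such as fluoro, methyl, methoxy or an amine, and whether the step with those groups would also differ from the one on the core of compound 1. They also leave open whether a hydrogen in place of the halogen would give a value close to those of the two halogens on either core.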